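Amino Group Restored on a Saturated Long-Chain Analogue

This account rests on a few compounds, and the source may have more. Where it says the series, first, only, none or still open, it means among the compounds named here.

Measured compounds in an assay on HEK293 cells for antagonist activity at transient receptor potential cation channel subfamily V member 2 (Rattus norvegicus), read by fluorescence and calcium flux, with a stated time of 5 min; a lower number here means a stronger inhibitor, a higher number a weaker inhibitor:
compound 1, `CCCCCCCC/C=C\CCCCCCCC[Se]C[C@H](N)C(=O)NCc1ccc(O)c(OC)c1`, gives 1700 nM
compound 2, `CCCCCCCCCCCCCCCC[Se]CCC(=O)NCc1ccc(O)c(OC)c1`, gives 4300 nM

Compound 2 stands at the highest of the two numbers; its nearest neighbour is compound 1, whose number is lower by a margin that lies beyond the usual scatter. Compound 3, `CCCCCCCCCCCCCCCC[Se]C[C@H](N)C(=O)NCc1ccc(O)c(OC)c1`, differs from compound 2 by amino in place of hydrogen on a saturated chain carbon bound to a carbonyl carbon and a saturated chain carbon. Compound 1 also carries an amino group at the same place, but its chain is not the same as that of compound 3, so no direct comparison of a single change is in hand. Compound 1 with the amino group gives 1700 nM, and that is the ground for the expectation. Compound 3 is therefore expected to show a step of a 1.7-fold lower number from compound 2 to compound 3 (0.24 log units; within the scatter) toward a lower number, landing between the two measured values. The estimate for compound 3 is 2500 nM, with a range from 1000 nM to 6000 nM.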

Compound 3, half-maximal inhibitory concentration: 1200 nM
For compound 3 the middle estimate is 2.1-fold (0.32 log units) above the measured one; low and high end bracket the measured number.
By their numbers in this assay, from the lowest: compounds 3 and 1 (each within the scatter of the next); then compound 2.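

In this assay, for the compounds shown here, the amino group on a saturated chain carbon bound to a carbonyl carbon and a saturated chain carbon now has a step of its own: adding it to the saturated compound gives a 3.6-fold lower number from compound 2 to compound 3 (0.55 log units; beyond the scatter), the first direct reading of a single change at this position. Octyl in place of dec-1-en-1-yl on a saturated chain carbon, eight bonds along the chain from a selenium atom, gives a 1.4-fold lower number from compound 1 to compound 3 (0.15 log units; within the scatter), so these two chains cannot be told apart in this assay. Nothing in the available data accounts for the effect of the amino group.

As far as these compounds go, it remains open whether a methylamino or hydroxyl group at the same carbon would match the amino group. Also open, from the compounds shown here alone, is how a shorter saturated chain would read.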